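The compounds below may be only part of what the source reports. "The series", "measured", "known", "first", "only" and "open" are said of these compounds alone.

Compound 1 `COC/C1=C/C[C@](C)(CCC=C(C)C)/C=C/[C@@H](OC(=O)C=C(C)C)[C@](C)(O)/C=C/C1=O`: 3950 nM
Compound 2 `C=C1/C=C/C(=O)/C(CO)=C\C[C@](C)(CCC=C(C)C)/C=C/[C@H]1OC(=O)C=C(C)C`: 3090 nM

Both numbers come from a functional assay on A549 cells (Homo sapiens) for antiproliferative activity, read by MTT assay, with a stated time of 48 h; a higher number here means a weaker inhibitor, a lower number a stronger inhibitor. Compound 1 carries the higher of the two numbers, yet compound 2 sits within the usual scatter of it, so the two cannot be told apart on these data. Compound 3 `CC(C)=CCC[C@]1(C)/C=C/[C@@H](OC(=O)C=C(C)C)[C@](C)(O)/C=C/C(=O)/C(C(=O)N2CCCC2)=C\C1` has not yet been measured in this assay. Set against compound 1, the change is (pyrrolidin-1-yl)carbonyl in place of methoxymethyl on a double-bonded ring carbon. Going by the values given here, no measured pair shows an exchange of this kind, so there is no step to lean on; all that can be said is that compound 1 and compound 2 give similar numbers. In this assay compound 3 is expected to give about 3000 nM, with a likely range from 900 nM to 10000 nM. The expected 1.3-fold lower number from compound 1 to compound 3 (0.12 log units; within the scatter) is small, at most near the edge of the scatter, with no direction the data support.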

Compound 3, half-maximal inhibitory concentration: 13000 nM
The estimate for compound 3 lay 4.3-fold (0.64 log units) below the measured number, outside the stated range (above it).
By their numbers in this assay, from the lowest: compounds 2 and 1 (each within the scatter of the next); then compound 3.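

At this double-bonded ring carbon the group matters: in this assay, (pyrrolidin-1-yl)carbonyl in place of methoxymethyl gives a 3.3-fold higher number from compound 1 to compound 3 (0.52 log units; beyond the scatter), a modest weakening that lies beyond the scatter. This is the only single-place change among the compounds shown, and it shows that the position accepts a larger group bearing a five-membered ring while the compound still gives a measurable number, though a weaker one. No measurement at hand explains the step.

As far as these compounds go, it remains open whether the weakening follows the ring, the carbonyl or the larger group as a whole. A (dimethylamino)carbonyl group, which keeps the carbonyl without the ring, or a carboxylic acid at this same carbon would help to separate these possibilities.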